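Ethoxy in Place of Nitro: An Expected Cytotoxicity Step

The compounds below may be only part of what the source reports. "The series", "measured", "known", "first", "only" and "open" are said of these compounds alone.

Of the compounds shown here, two have so far been tested in an ADME assay on MCF-10A cells (Homo sapiens) for cytotoxicity, read by WST assay, with a stated time of 48 h; a higher number here means a weaker inhibitor, a lower number a stronger inhibitor. Compound 1 `O=C(NNC(=S)Nc1ccccc1[N+](=O)[O-])c1ccncc1` carries a nitro group on its aromatic ring. In this assay compound 1 reaches only a limit, reported as > 300000 nM. Compound 2 `O=C(NNC(=S)Nc1ccc([N+](=O)[O-])cc1)c1ccncc1` is the second member of the pair. In this assay compound 2 likewise reaches only a limit, reported as > 300000 nM. Compound 2 thus stands at the upper edge of what has been seen, since (the limit of > 300000 nM in this assay, at which 2 of the 2 values shown sit), and no number has been obtained for it. The untested compound 3 `CCOc1ccc(NC(=S)NNC(=O)c2ccncc2)cc1` differs from compound 2 in a single place: ethoxy in place of nitro on an aromatic carbon, in words ethoxy in place of nitro on an aromatic carbon. Among the measured compounds shown here, no measured step between compounds matches this change, so there is nothing to calibrate it against. The step from compound 2 to compound 3 in this assay is expected to be none beyond the scatter, so that a number no higher from compound 2 to compound 3 (the limit leaves the size open) is the estimate. Compound 3 is expected to give 300000 nM in this assay, within 100000 nM to 1000000 nM, most probably reported once more only as a limit.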

Compound 3, half-maximal inhibitory concentration: > 300000 nM
Compound 3 gave a limit, no number (the forecaster's own chance of this, stated with the estimate: 80%); the middle value sits exactly at the limit.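

No step can be read from compound 2 to compound 3, because each gives only a limit and no number: the limit of > 300000 nM in this assay, at which 3 of the 3 values shown sit. The compounds shown leave open how far any of them lies from that limit, and whether ethoxy in place of nitro on an aromatic carbon shifts the read-out at all.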